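A few compounds are considered here, and "the series" means these few. Any claim that something is new, unique, unknown or untested is made for them only; others in the source may bear on it.

Measured in a physicochemical assay for solubility, with a stated time of 3 days, at pH 2; a higher number here means a more soluble compound, a lower number a less soluble compound:
- compound 1 `NC(=O)c1ccc2[nH]c(-c3ccc(OCCC4CCN(Cc5ccccc5)CC4)cc3)nc2c1`: 110000 nM
- compound 2 `CC(=O)N1CCCC(COc2ccc(-c3nc4cc(C(N)=O)ccc4[nH]3)cc2)C1`: "not determined" (no result reported)

Compound 2 has no number to stand on: its entry reads "not determined" (no result reported), so it cannot be placed above or below compound 1. Compound 3 `CC(=O)N1CCC(CCOc2ccc(-c3nc4cc(C(N)=O)ccc4[nH]3)cc2)CC1` has not yet been measured. The structural change is (1-acetylpiperidin-4-yl)methyl in place of 1-acetylpiperidin-3-yl on a saturated chain carbon bound to an oxygen on an aromatic ring. Going by the values given here, no measured step exists to guide the size of this change in this assay. The expectation is therefore modest: no step beyond the usual scatter, in either direction. Among the compounds with values here, the only number available comes from compound 1 at 110000 nM, so that value serves as a loose anchor, and the range stays wide. For compound 3 the expected value is 100000 nM, with an estimated range from 30000 nM to 300000 nM.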

Compound 3, solubility: 87000 nM
For compound 3 the middle estimate is 1.1-fold (0.06 log units) above the measured one; the measured number falls inside the stated range.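

In this assay, acetyl in place of benzyl on an amine nitrogen in a ring gives a 1.3-fold lower number from compound 1 to compound 3 (0.10 log units; within the scatter), so this first measured step at that nitrogen does not separate the two groups in this read-out. The step from compound 2 to compound 3, with (1-acetylpiperidin-4-yl)methyl in place of 1-acetylpiperidin-3-yl, cannot be read, as compound 2 has no number to compare. Nothing measured here offers an explanation for the result.

From the compounds shown here alone, whether other groups on that ring nitrogen would also stay within the scatter remains open, for example a methyl group, a sulfonamide or a carboxylic acid on a short chain. Going by these compounds, it is also open how a longer chain between the ring and the oxygen on the aromatic ring would read in this assay.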